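Notes on the shared core: methyl removed from an oxygen

A few compounds are considered here, and "the series" means these few. Any claim that something is new, unique, unknown or untested is made for them only; others in the source may bear on it.

Measured so far:
compound 1 `COc1cc(OC)c(C(=O)/C=C/c2ccccc2SC)c(OC)c1` — 0.3%
compound 2 `COc1cccc(/C=C/C(=O)c2c(OC)cc(OC)cc2OC)c1` — 0.3%

In a functional assay on Huh-7 cells (Homo sapiens), read by fluorescence and BrdU incorporation, with a stated time of 48 h, tested at 25 uM (a higher number here means a weaker effect of the compound at the concentration tested, a lower number a stronger effect), compound 1 gives 0.3%, and compound 2 gives 0.3%. Both numbers sit near the bottom of the read-out. For the measured compounds named here, the only measured step, no change at the digits printed from compound 1 to compound 2 (within the scatter), swaps the aryl end of the chain and leaves the read-out where it was. Going by the values given here, compound 2 therefore stands level with compound 1, its only neighbour among the measured compounds.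

Compound 3 `COc1cccc(/C=C/C(=O)c2c(O)cc(OC)cc2OC)c1` differs from compound 2 at the core: hydrogen in place of methyl on an oxygen on an aromatic ring. Among the compounds with values here, no measured step touches an oxygen on the core; the one step measured lies at the other end of the molecule and was flat, so nothing measured speaks directly to this change. Since compound 2 gives the low value 0.3%, a change beyond the scatter could only read as weakening. A small step of size a number 2.7 percentage points higher from compound 2 to compound 3 (within the scatter) is expected, most likely not beyond the scatter. For compound 3 the estimate in this assay is 3%, with a range from 0% to 30%.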

Compound 3, a percentage reported as activity, at one concentration (the size of the read-out at that concentration, not a potency): 8.5%
Beside the measured number, compound 3's estimate is 5.5 percentage points below it; measured number inside the range.
By their numbers in this assay, from the lowest: compounds 1, 2 and 3 (each within the scatter of the next).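

In this assay, for the compounds shown here, the step of a number 8.2 percentage points higher from compound 2 to compound 3 (within the scatter) is the first reading at an oxygen on the core, whereas the earlier step touched only the aryl end of the chain. With hydrogen in place of methyl on this oxygen on an aromatic ring, the read-out stays within the scatter, so at the one concentration tested, the methyl on this oxygen is not required to keep the read-out level with that of compound 2. No measured property of these compounds bears on this result, so it stands as an observation without an explanation.

A single concentration gives no potency, so the compounds shown leave open whether compound 2 and compound 3 would also stay level at lower concentrations. Also open, on these data alone, is whether an ethoxy group or an amine on the core at this place, or hydroxy in place of either of the other two methoxy groups on the core, would stay within the scatter as methoxy to hydroxy does here.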